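Exchanging the aryl group on the saturated ring carbon

The compounds below may be only part of what the source reports. "The series", "measured", "known", "first", "only" and "open" are said of these compounds alone.

In a functional assay on MCF7 cells (Homo sapiens) for antiproliferative activity, read by MTT assay, with stated times of 24 h and 72 h (a lower number here means a stronger inhibitor, a higher number a weaker inhibitor), compound 2 (`COc1cc([C@@H]2[C@H](Oc3ccccc3)C(=O)N2c2cc(OC)c(OC)c(OC)c2)ccc1O`) reads 32000 nM and stands level, within the scatter, with compound 1 (`COc1cc(N2C(=O)[C@@H](Oc3ccccc3)[C@H]2c2ccc(C#N)cc2)cc(OC)c1OC`) at 31600 nM. Compound 3 (`COc1cc(N)c([C@@H]2[C@H](Oc3ccccc3)C(=O)N2c2cc(OC)c(OC)c(OC)c2)cc1O`) differs from compound 2 at one place (a group of 10 heavy atoms (7 carbon, 1 nitrogen, 2 oxygen; one six-membered aromatic ring of carbon only) in place of a group of 9 heavy atoms (7 carbon, 2 oxygen; one six-membered aromatic ring of carbon only), on a saturated ring carbon). Among the measured compounds shown here, the only measured step at this carbon (a 1.0-fold higher number from compound 1 to compound 2 (0.01 log units; within the scatter)) lies within the scatter, and this single step is a weak guide to a new group. On that thin evidence, a moderate move towards a lower number is expected, with wide uncertainty (a 6.4-fold lower number from compound 2 to compound 3 (0.81 log units; beyond the scatter)). For compound 3 the estimate is 5000 nM, with an expected range from 200 nM to 40000 nM.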

Compound 3, half-maximal inhibitory concentration: 20000 nM
Estimate against measurement, compound 3: 4.0-fold (0.60 log units) below; low and high end bracket the measured number.
By their numbers in this assay, from the lowest: compounds 3, 1 and 2 (each within the scatter of the next).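

In this assay, a third aryl group on this saturated ring carbon still leaves the reading level with both earlier compounds (a 1.6-fold lower number from compound 2 to compound 3 (0.20 log units; within the scatter); a 1.6-fold lower number from compound 1 to compound 3 (0.20 log units; within the scatter)). Across the nitrile-bearing, hydroxy-and-methoxy-bearing and nitrogen-bearing aryl groups of compounds 1, 2 and 3, this position has thus shown no separation. No accompanying measurement bears on this result.

Still open, going by these compounds, is whether a carboxylic acid on this aryl ring, or a cyclohexyl group in its place, would move the reading beyond the scatter.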